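Trimming the side chain of a thioether inhibitor

This account rests on a few compounds, and the source may have more. Where it says the series, first, only, none or still open, it means among the compounds named here.

Measured so far:
Compound 1, `Cn1ncc2c(=O)n(-c3ccccc3)c(COc3cccc(F)c3)nc21`: 780 nM
Compound 2, `Cn1ncc2c(=O)n(-c3ccccc3)c(SC(C)(C)c3ccccc3)nc21`: 1390 nM
Compound 3, `CC(C)C(Sc1nc2c(cnn2C)c(=O)n1-c1ccccc1)c1ccccc1`: 130 nM

Of the compounds shown here, three sharing one core have been tested in an assay on isolated protein for inhibition of Retinaldehyde dehydrogenase 3 (Homo sapiens); a higher number here means a weaker inhibitor, a lower number a stronger inhibitor. Compound 1 gives 780 nM, compound 2 gives 1390 nM, and compound 3 gives 130 nM. Compound 3 stands lowest of the three, and its distance from both compound 1 and compound 2 lies beyond the usual scatter, so it is the strongest inhibitor of this set.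

Compound 4, `CCC(Sc1nc2c(cnn2C)c(=O)n1-c1ccccc1)c1ccccc1`, has not yet been measured in this assay. It differs from compound 3 in one place: hydrogen in place of methyl on a saturated chain carbon bound to two saturated chain carbons. Among the measured compounds shown here, no step between measured compounds matches this change, so the expectation rests on compound 3 alone. A small shift toward a higher number, or none beyond the scatter, is expected, since only a single carbon is removed from the chain. The step from compound 3 to compound 4 is expected to be a 1.9-fold higher number from compound 3 to compound 4 (0.28 log units; within the scatter). Compound 4 is estimated at 250 nM, within a range from 90 nM to 700 nM.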

Compound 4, half-maximal inhibitory concentration: 119 nM
Compound 4: middle estimate off by 2.1-fold (0.32 log units), on the high side; low and high end bracket the measured number.
By their numbers in this assay, from the lowest: compounds 4 and 3 (each within the scatter of the next); then compounds 1 and 2 (each within the scatter of the next).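

In this assay, the isopropyl to ethyl change on the saturated chain carbon gives a 1.1-fold lower number from compound 3 to compound 4 (0.04 log units; within the scatter) and so shows that this methyl can be removed without a shift beyond the scatter. The placing of carbons in the group on the sulfur can still matter: 1-phenylpropyl in place of 1-methyl-1-phenylethyl gives a 12-fold lower number from compound 2 to compound 4 (1.07 log units; beyond the scatter) and is a large step, even though compound 2 and compound 4 share the same core. Nothing shown here accounts for either step.

The compounds shown leave open whether a methyl or a longer propyl chain on this carbon would keep the number in the range of compound 3 and compound 4. They also leave open how an amine or a carboxylic acid would fare in that chain.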